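Compound 4: 2,5-dichlorophenyl in place of 4-bromophenyl

The source may hold more compounds than are shown below. What is called first, only, known or untested is meant among the compounds shown, and "the series" means these compounds.

Compound 1 (`Nc1ccccc1NC(=O)CCCNCC(=O)Nc1ccc(Br)cc1`) is the reference point for this step in a functional assay on HCT-116 cells (Homo sapiens) for inhibition, read by MTT assay, with a stated time of 2 days; on this read-out lower numbers stand for higher toxicity in this test and higher numbers for lower toxicity in this test. Compound 1 gives > 100000 nM as a limit of the assay, not a number. Compound 2 (`Nc1ccccc1NC(=O)c1ccc(NCC(=O)Nc2ccc([N+](=O)[O-])cc2)cc1`) gives > 100000 nM, which is also a limit. Compound 3 (`Nc1ccccc1NC(=O)c1ccc(NCC(=O)Nc2cccc([N+](=O)[O-])c2)cc1`) gives > 100000 nM, again a limit. Compound 1 therefore has no numerical position in the series, and the record amounts to the limit of > 100000 nM in this assay, at which 3 of the 3 values shown sit, and nothing more.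

Compound 4 (`Nc1ccccc1NC(=O)CCCNCC(=O)Nc1cc(Cl)ccc1Cl`) differs from compound 1 in one place. The change is 2,5-dichlorophenyl in place of 4-bromophenyl on an amide-type nitrogen and puts 2,5-dichlorophenyl in place of 4-bromophenyl on an amide-type nitrogen.

For the measured compounds named here, the one measured step that changes a group at such a nitrogen is a step that the two limits leave unreadable from compound 2 to compound 3 and it offers no size to carry over. Going by the values given here, since compound 1 holds only the limit > 100000 nM and no measured step has a readable size, no step beyond the scatter is expected, and no direction can be favoured. The expected change is a number no higher from compound 1 to compound 4 (the limit leaves the size open) and this remains an estimate. Compound 4 is estimated at 100000 nM with an expected range of 40000 nM to 200000 nM in this assay.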

Compound 4, concentration lethal to 50% of the cells: > 100000 nM
Compound 4: a limit, no number; the forecaster's own chance of this, stated with the estimate: 75%; the middle value sits exactly at the limit.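

In this assay compound 1 and compound 4 both stand as limits, not numbers, so no step between them can be read: the limit of > 100000 nM in this assay, at which 4 of the 4 values shown sit.

The compounds shown leave open how far the group on the amide-type nitrogen can shift this read-out, and whether any of them gives a number in this assay at all.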